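This account rests on a few compounds, and the source may have more. Where it says the series, first, only, none or still open, it means among the compounds named here.

Measured compounds:
compound 1 `O=C1O/C(=C\Cn2ncc(=O)[nH]c2=O)C(OCc2ccccc2)=C1OCc1ccccc1` — 41300 nM
compound 2 `NC1(CCn2ncc(=O)[nH]c2=O)OC(=O)C(OCc2ccccc2)=C1OCc1ccccc1` — a limit of the assay, > 100000 nM
compound 3 `NC1(CCn2cc(F)c(=O)[nH]c2=O)OC(=O)C(OCc2ccccc2)=C1OCc1ccccc1` — 42800 nM

In a functional assay on HepG2 cells (Homo sapiens) for inhibition, read by MTT assay, with a stated time of 72 h (a higher number here means a weaker inhibitor, a lower number a stronger inhibitor), compound 1 and compound 3 give numbers within the usual scatter of each other. Compound 2 reached only a limit of the assay, (the limit of > 100000 nM in this assay, at which 1 of the 3 values shown sits). The unmeasured compound 4 `O=C1O/C(=C\Cn2c(=O)[nH]c(=O)[nH]c2=O)C(OCc2ccccc2)=C1OCc1ccccc1` differs from compound 1 by a group of 9 heavy atoms (3 carbon, 3 nitrogen, 3 oxygen; one six-membered aromatic ring with 3 hetero atoms) in place of a group of 8 heavy atoms (3 carbon, 3 nitrogen, 2 oxygen; one six-membered aromatic ring with 3 hetero atoms), on a saturated chain carbon bound to a double-bonded chain carbon. Among the measured compounds shown here, only one measured step, an at least 2.3-fold lower number from compound 2 to compound 3 (0.36 log units; beyond the scatter), bears on an exchange of the ring on the chain, and it started from a limit, so its full size is not known; it also concerns a different core and a different ring. For the measured compounds named here, since no measured step replaces the ring of compound 1 with the ring entering in compound 4, the expectation rests on compound 1 alone, and the step of a 1.2-fold higher number from compound 1 to compound 4 (0.08 log units; within the scatter) is estimated to stay within or near the scatter, in no firm direction. Compound 4 is therefore expected to give about 50000 nM, between 15000 nM and 150000 nM.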

Compound 4, half-maximal inhibitory concentration: 44800 nM
For compound 4 the middle estimate is 1.1-fold (0.05 log units) above the measured one, within the range that was stated.
By their numbers in this assay, from the lowest: compounds 1, 3 and 4 (each within the scatter of the next). At a limit, above all of these: compound 2.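

In this assay, exchanging the group of 8 heavy atoms for the group of 9 heavy atoms, on a saturated chain carbon bound to a double-bonded chain carbon, gives a 1.1-fold higher number from compound 1 to compound 4 (0.04 log units; within the scatter). Among the compounds shown here, this is the first direct reading of a ring exchange at this position on the core of compound 1, and it shows that the added oxygen and the added hydrogen-bond donor leave the number within the scatter. No measurement shown here gives a cause for this result.

The compounds shown leave open whether an amine or a carboxylic acid on the entering ring, or a longer chain at this place, would move the number beyond the scatter. They also leave open whether the group of 9 heavy atoms would behave the same way on the core of compound 3.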